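Amino in Place of Methoxy: From Compound 1 to Compound 3

A few compounds are considered here, and "the series" means these few. Any claim that something is new, unique, unknown or untested is made for them only; others in the source may bear on it.

compound 1, `COc1nc(Cl)nc2c1ncn2[C@H]1C[C@H](N=[N+]=[N-])[C@@H](CO)O1`: > 100000 nM
compound 2, `COc1nc(F)nc2c1ncn2[C@H]1C[C@H](N=[N+]=[N-])[C@@H](CO)O1`: > 100000 nM

In an ADME assay on CCRF-CEM cells (Homo sapiens) for cytotoxicity, with a stated time of 5 days (on this read-out higher numbers stand for weaker inhibition and lower numbers for stronger inhibition), compound 1 gives > 100000 nM. That value is a limit of the assay and not a number. Compound 2 gives > 100000 nM in this assay. This too is a limit. Among the measured compounds shown here, the only measured step, a step that the two limits leave unreadable from compound 1 to compound 2, is fluoro in place of chloro on an aromatic carbon, and its size cannot be read because of the limit of > 100000 nM in this assay, at which 2 of the 2 values shown sit. Compound 1 therefore stands at that limit, as does the one other compound shown.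

Compound 3, `[N-]=[N+]=N[C@H]1C[C@H](n2cnc3c(N)nc(Cl)nc32)O[C@@H]1CO`, differs from compound 1 by amino in place of methoxy on an aromatic carbon. For the measured compounds named here, no measured step touches this position, and the one step that is known is unreadable, so nothing among the measured compounds gives a size or a direction for this change in this assay. Compound 3 is accordingly expected to sit close to where compound 1 sits, with a step of an at least 1.6-fold lower number from compound 1 to compound 3 (0.22 log units; that floor lies within the scatter) as the estimate. The estimate for compound 3 in this assay is 60000 nM, with a range from 3000 nM to 150000 nM.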

Compound 3, half-maximal inhibitory concentration: > 100000 nM
Compound 3 was reported as a limit (the forecaster's own chance of this, stated with the estimate: 55%); middle value at least 1.6-fold (0.22 log units) away from the limit.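

In this assay compound 3 gives > 100000 nM, which is a limit of the assay and not a number. The step between compound 1 and compound 3 therefore cannot be read: the limit of > 100000 nM in this assay, at which 3 of the 3 values shown sit. The compounds shown leave open how far each lies from that limit, and whether amino in place of methoxy changes the read-out at all.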